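Methyl position on the anilide of the shared core

The source may hold more compounds than are shown below. What is called first, only, known or untested is meant among the compounds shown, and "the series" means these compounds.

Compound 1 `Cc1ccc(NC(=O)c2c(O)c3cccnc3n(-c3ccccc3)c2=O)cc1` gives -3.5% in a functional assay on the whole organism for inhibition, with Rattus norvegicus as the target, read by paw edema, at a dose of 100 mg/kg by the oral route; a lower number here means less inhibition, a higher number more inhibition at the dose given (going by the name of the read-out). Among the three measured compounds it stands second highest. Its nearest neighbour is compound 2 `Nc1ccc(NC(=O)c2c(O)c3cccnc3n(-c3ccccc3)c2=O)cc1`, which gives -5.5%, a step of a number 2 percentage points lower from compound 1 to compound 2 (within the scatter) that stays within the scatter, while furthest from it is compound 3 `Cc1cccc(NC(=O)c2c(O)c3cccnc3n(-c3ccccc3)c2=O)c1`, which gives 14.2%, a step of a number 17.7 percentage points higher from compound 1 to compound 3 (beyond the scatter) that lies beyond it. Compound 2 to compound 3 reads a number 19.7 percentage points higher from compound 2 to compound 3 (beyond the scatter).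

Compound 4 `Cc1ccccc1NC(=O)c1c(O)c2cccnc2n(-c2ccccc2)c1=O` differs from compound 1 by 2-methylphenyl in place of 4-methylphenyl on an amide-type nitrogen. Within the data shown here, no measured pair carries the methyl to this position, so the only steps that bear on it are those that move the methyl elsewhere on the same ring: the modest rises a number 17.7 percentage points higher from compound 1 to compound 3 (beyond the scatter) and a number 19.7 percentage points higher from compound 2 to compound 3 (beyond the scatter). Those steps say that shifting the methyl away from the 4-position can lift the read-out, but they do not fix the direction for the 2-position. The expected step is therefore small, a number 8.5 percentage points higher from compound 1 to compound 4 (within the scatter), leaning upward but not clearly beyond the scatter. Compound 4 is estimated at 5%, within a range of -10% to 20%.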

Compound 4, a percentage reported as inhibition, in the whole organism at one dose (the size of the read-out at that dose, not a potency): 11.7%
Compound 4: middle estimate off by 6.7 percentage points, on the low side; the range from low to high includes it.
By their numbers in this assay, from the lowest: compounds 2 and 1 (each within the scatter of the next); then compounds 4 and 3 (each within the scatter of the next).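

Among these compounds, the step of a number 15.2 percentage points higher from compound 1 to compound 4 (beyond the scatter) is of the same modest size as the rise seen for the 3-methylphenyl anilide, and a number 17.2 percentage points higher from compound 2 to compound 4 (beyond the scatter) points the same way, so in this assay both 4-substituted anilides now stand apart from both other methyl isomers, with no compound of the four against this split. The step of a number 2.5 percentage points lower from compound 3 to compound 4 (within the scatter) does not separate 2-methylphenyl from 3-methylphenyl, so the read-out here tells only that the methyl is not in the 4-methylphenyl arrangement, not which of the other two arrangements is preferred. Nothing at hand explains this difference between the isomers.

An unsubstituted phenyl on the amide nitrogen would show whether the 4-substituted anilides lose inhibition or the other two gain it. From the compounds shown here alone, whether a chlorine or methoxy group can take the place of the methyl in the 2-methylphenyl and 3-methylphenyl anilides remains open.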